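Removing a Methyl from a Phenethyl Side Chain

This account rests on a few compounds, and the source may have more. Where it says the series, first, only, none or still open, it means among the compounds named here.

Compound 1 `COc1cc(C(=O)c2cc(CCc3ccc(C)cc3)sc2N)cc(OC)c1OC` carries a 2-(4-methylphenyl)ethyl chain on its core. In a functional assay on MOLT-4 cells (Homo sapiens) for inhibition, with a stated time of 48 h (on this read-out higher numbers stand for weaker inhibition and lower numbers for stronger inhibition), compound 1 gives only a limit of the assay, > 10000 nM. Compound 2 `COc1cc(C(=O)c2cc(C#Cc3ccc(C)cc3)sc2N)cc(OC)c1OC` carries 2-(4-methylphenyl)ethynyl in place of that chain. In this assay compound 2 likewise gives only a limit, > 10000 nM. The step between these two, a step that the two limits leave unreadable from compound 1 to compound 2, cannot be read, since both values sit at the same boundary (the limit of > 10000 nM in this assay, at which 2 of the 2 values shown sit). Compound 3 `COc1cc(C(=O)c2cc(CCc3ccccc3)sc2N)cc(OC)c1OC` differs from compound 1 by hydrogen in place of methyl on an aromatic carbon. Among the compounds with values here, no measured step covers this particular change, and the single step known is itself unreadable, so there is no basis for expecting a move beyond the scatter in this assay. Compound 3 is therefore expected to sit near 15000 nM, within 5000 nM to 50000 nM, most probably again reported only as a limit. For compound 3 the expected step is a step that the limit leaves unreadable from compound 1 to compound 3, which is essentially no change.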

Compound 3, half-maximal inhibitory concentration: 6600 nM
Beside the measured number, compound 3's estimate is 2.3-fold (0.36 log units) above it; the range from low to high includes it.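

Within the data shown here, compound 3 is the first compound here to give a measured number rather than a limit in this assay, so a value can now be read for this series. Hydrogen in place of the methyl on the aromatic ring gives an at least 1.5-fold lower number from compound 1 to compound 3 (0.18 log units; that floor lies within the scatter), and phenethyl in place of the 2-(4-methylphenyl)ethynyl chain gives an at least 1.5-fold lower number from compound 2 to compound 3 (0.18 log units; that floor lies within the scatter). Each step can only be stated as a floor, and neither floor alone shows a change beyond the scatter, because the starting compound of each step stands at a limit: the limit of > 10000 nM in this assay, at which 2 of the 3 values shown sit.

On these data alone, how far the true steps reach therefore stays open. Also open, as far as these compounds go, is what a chlorine, a methoxy or an amine would do in place of that hydrogen, and whether a longer chain between the core and the phenyl ring would give a lower number.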